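Replacing bromo with fluoro on compound 1

A few compounds are considered here, and "the series" means these few. Any claim that something is new, unique, unknown or untested is made for them only; others in the source may bear on it.

- Compound 1 `N#Cc1ccc(NC(=O)c2cccc(Br)c2O)cc1`: 2910 nM
- Compound 2 `N#Cc1ccc(NC(=O)c2cc(Br)ccc2O)cc1`: 620 nM
- Compound 3 `N#Cc1ccc(NC(=O)c2cc(Cl)c(-c3ccccc3)cc2O)cc1`: 520 nM

In a functional assay on HL-60 cells (Homo sapiens) for cytotoxicity, read by luminescence and CellTiter-Glo, with a stated time of 3 days (on this read-out higher numbers stand for weaker inhibition and lower numbers for stronger inhibition), compound 1 gives the highest of the three numbers, 2910 nM. Compound 2 and compound 3 both lie lower, and each gap is beyond the scatter. The next compound, compound 4 `N#Cc1ccc(NC(=O)c2cccc(F)c2O)cc1`, has not yet been measured. It carries fluoro in place of bromo on an aromatic carbon, ortho to a hydroxy group (fluoro in place of bromo on an aromatic carbon). For the measured compounds named here, no measured pair isolates this swap, so the expectation is only tentative. The estimated change is a 1.4-fold higher number from compound 1 to compound 4 (0.14 log units; within the scatter), expected to be a small step toward a higher number and not beyond the scatter. Compound 4 is expected at 4000 nM. Its estimated range runs from 1500 nM to 11000 nM.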

Compound 4, half-maximal inhibitory concentration: 5390 nM
For compound 4 the middle estimate is 1.3-fold (0.13 log units) below the measured one; low and high end bracket the measured number.
By their numbers in this assay, from the lowest: compounds 3 and 2 (each within the scatter of the next); then compounds 1 and 4 (each within the scatter of the next).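

For the compounds shown here, this is the first step in the set that isolates one place: in this assay, fluoro in place of bromo on this aromatic carbon, ortho to a hydroxy group, gives a 1.9-fold higher number from compound 1 to compound 4 (0.27 log units; within the scatter). At this position, therefore, the two halogens cannot be told apart on this read-out. Nothing shown accounts for this result.

Whether the position accepts only halogens stays open, as the compounds shown include no amine, methoxy group or carboxylic acid there. Going by these compounds, whether the same swap behaves alike elsewhere on the core also remains unknown.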